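Ethoxy to trifluoroethoxy on a cyclopropane hydrazide

This account rests on a few compounds, and the source may have more. Where it says the series, first, only, none or still open, it means among the compounds named here.

Compound 1 `O=C(NNC(=O)C1CC1c1ccc(OC(F)(F)F)cc1)c1ccncc1`: "not determined" (no result reported)
Compound 2 `CCOc1ccc(C2CC2C(=O)NNC(=O)c2ccncc2)cc1`: "not determined" (no result reported)
Compound 3 `O=C(NNc1nncc2ccccc12)C1CC1c1ccc(OCC(F)(F)F)cc1`: 29000 nM

In a functional assay on SK-MEL cells (Homo sapiens) for inhibition, read by MTT assay, with a stated time of 72 h (a lower number here means a stronger inhibitor, a higher number a weaker inhibitor), compound 2 has no reported number, and the same holds for compound 1, so compound 2 cannot be placed on any scale. Among the compounds with values here, compound 3 is the only compound with a value in this assay. Compound 4 `O=C(NNC(=O)C1CC1c1ccc(OCC(F)(F)F)cc1)c1ccncc1` is compound 2 with trifluoromethyl in place of methyl on a saturated chain carbon bound to an oxygen on an aromatic ring. Within the data shown here, no step between two measured compounds is available, so neither the size nor the direction of this change can be read from the data. Compound 4 does share its 2,2,2-trifluoroethoxy group with compound 3, which in this assay gives 29000 nM. On that comparison alone, compound 4 is expected to give roughly 30000 nM, within an estimated range from 8000 nM to 100000 nM.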

Compound 4, half-maximal inhibitory concentration: 81000 nM
The estimate for compound 4 lay 2.7-fold (0.43 log units) below the measured number; the measured number falls inside the stated range.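

Within the data shown here, with no reported number for compound 2 in this assay, no step to compound 4 can be read. From the compounds shown here alone, the effect of changing ethoxy to 2,2,2-trifluoroethoxy on inhibition therefore stays open. No supporting data bear on this result.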